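The source may hold more compounds than are shown below. What is called first, only, known or untested is meant among the compounds shown, and "the series" means these compounds.

Of the compounds shown here, three built on the same core have been tested in a functional assay (Homo sapiens) for antiproliferative activity, read by resazurin assay, with a stated time of 48 h, tested at 5 uM; a lower number here means a weaker effect, a higher number a stronger effect of the compound at the concentration tested. Compound 1 `COc1cc(OC)c2c(=O)cc(-c3ccc(OCC(O)CN4CCCC4)cc3)oc2c1` gives 21% in this assay. Compound 2 `COc1cc(OC)c2c(=O)cc(-c3ccc(OCC(O)CN(C)C)cc3)oc2c1` gives 42%. Compound 3 `COc1cc(OC)c2c(=O)cc(-c3ccc(NCCN(C)C)cc3)oc2c1` gives 30%, which places it second highest of the three: its gap to compound 1 is within the scatter, while the step of a number 12 percentage points lower from compound 2 to compound 3 (beyond the scatter) is beyond it. For the measured compounds named here, the only measured step that exchanges these two amine groups is the one in which a number 21 percentage points higher from compound 1 to compound 2 (beyond the scatter); there the change sat two bonds along the chain from an oxygen on a saturated carbon, not from a nitrogen on an aromatic ring, so it is a guide rather than a rule. Compound 4 `COc1cc(OC)c2c(=O)cc(-c3ccc(NCCN4CCCC4)cc3)oc2c1` has not yet been measured. It differs from compound 3 in one place: pyrrolidin-1-yl in place of dimethylamino on a saturated chain carbon, two bonds along the chain from a nitrogen on an aromatic ring. This is the reverse of the exchange between compound 1 and compound 2, so a fall of roughly that size is expected, with wide uncertainty given the different chain. Compound 4 is expected to give 15% in this assay, within 2% to 30%. The expected step, a number 15 percentage points lower from compound 3 to compound 4 (beyond the scatter), is a modest fall.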

Compound 4, a percentage reported as inhibition, at one concentration (the size of the read-out at that concentration, not a potency): 21%
For compound 4 the middle estimate is 6 percentage points below the measured one; measured number inside the range.
By their numbers in this assay, from the lowest: compounds 1, 4 and 3 (each within the scatter of the next); then compound 2.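

In this assay, exchanging dimethylamino for pyrrolidin-1-yl on a saturated chain carbon, two bonds along the chain from a nitrogen on an aromatic ring, gives a number 9 percentage points lower from compound 3 to compound 4 (within the scatter), so at this position the two amine groups cannot be told apart. The same exchange was readable on the 3-(dimethylamino)-2-hydroxypropoxy chain, yet the two steps cannot be firmly separated from each other: the same change on two cores in this assay, a number 21 percentage points higher (beyond the scatter) from compound 1 to compound 2 and a number 9 percentage points higher (within the scatter) from compound 4 to compound 3, 12 percentage points apart, within the scatter of two such steps. With pyrrolidin-1-yl at the chain end, replacing the 2-hydroxy-3-(pyrrolidin-1-yl)propoxy group with the (2-(pyrrolidin-1-yl)ethyl)amino group gives no change at the digits printed from compound 1 to compound 4 (within the scatter), while replacing the 3-(dimethylamino)-2-hydroxypropoxy group with that same group gives a number 21 percentage points lower from compound 2 to compound 4 (beyond the scatter), which leaves compound 2 apart from the other three.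

Going by these compounds, whether the effect of dimethylamino truly depends on the chain that carries it remains open, since these few single readings at one concentration cannot settle it. Also open, on these data alone, is how a piperidin-1-yl or morpholin-4-yl group, or a longer chain between the nitrogen on the aromatic ring and the amine, would read in this assay.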